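The source may hold more compounds than are shown below. What is called first, only, known or untested is meant among the compounds shown, and "the series" means these compounds.

Measured compounds in an in vitro functional assay on SH-SY5Y cells for agonist activity at Neuronal acetylcholine receptor; alpha3/beta4 (Homo sapiens), read by FLIPR and calcium flux; a higher number here means that more compound is needed for the effect, a lower number that less compound is needed:
- compound 1, `COc1cncc(C2=CC3CC(C2)CN(C)C3)c1`, gives 3640 nM
- compound 2, `Clc1ccncc1C1=CC2CNCC(C1)C2`, gives 377 nM
- compound 3, `Clc1ccc(C2=CC3CNCC(C2)C3)cn1`, gives 16 nM

Of the three numbers, compound 3 has the lowest, so the least compound is needed for its effect. The nearest to it is compound 2, whose number is higher by a margin beyond the scatter, and compound 1 stands further still. Compound 4, `Fc1ccc(C2=CC3CNCC(C2)C3)cn1`, is not yet measured. It differs from compound 3 in one place: fluoro in place of chloro on an aromatic carbon. Among the compounds with values here, no pair of measured compounds shows the effect of this swap, so the step can only be guessed. A small rise in the number is expected, a 2.2-fold higher number from compound 3 to compound 4 (0.34 log units; beyond the scatter), close to the scatter. Compound 4 is therefore estimated at 35 nM, between 10 nM and 120 nM.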

Compound 4, half-maximal effective concentration: 99 nM
Estimate against measurement, compound 4: 2.8-fold (0.45 log units) below, and the stated range covers the measured number.
By their numbers in this assay, from the lowest: compound 3; then compound 4; then compound 2; then compound 1.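

In this assay, putting fluoro in place of chloro on this aromatic carbon, next to the ring nitrogen, gives a 6.2-fold higher number from compound 3 to compound 4 (0.79 log units; beyond the scatter). Within the data shown here, this is the first direct reading of a single change on the shared core: the position responds to which halogen it carries, and chloro gives the lower number of the two. No measurement at hand offers a reason for this step. Still open, as far as these compounds go, is how a bromo, methyl or nitrile group on the same carbon would compare, and whether this swap gives a similar step on other cores.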